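This account rests on a few compounds, and the source may have more. Where it says the series, first, only, none or still open, it means among the compounds named here.

Measured in a functional assay on MV4-11 cells (Homo sapiens) for inhibition, read by luminescence, with a stated time of 72 h; on this read-out lower numbers stand for stronger inhibition and higher numbers for weaker inhibition:
- compound 1 `CC(=O)c1c(C)c2ccc(Nc3nccc(-c4cccnc4)n3)cc2oc1=O`: 12900 nM
- compound 2 `CCN1C(=O)COc2c(CN3CCCCC3)cc(Nc3ncc(F)c(-c4ccc(F)cc4OC)n3)cc21`: 50 nM
- compound 3 `CCN1C(=O)COc2c(CN3CCN(C(C)=O)CC3)cc(Nc3ncc(F)c(-c4ccc(F)cc4OC)n3)cc21`: 17 nM

Compound 3 has the lowest number of the three, with compound 2 the nearest and compound 1 the furthest. Next in the series is compound 4 `CCN1C(=O)COc2c(CN3CCC(N(C)C)C3)cc(Nc3ncc(F)c(-c4ccc(F)cc4OC)n3)cc21`, not yet measured in this assay. The change from compound 3 is 3-(dimethylamino)pyrrolidin-1-yl in place of 4-acetylpiperazin-1-yl on a saturated chain carbon bound to an aromatic carbon.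

Going by the values given here, only one measured step bears on this place, a 2.9-fold lower number from compound 2 to compound 3 (0.47 log units; beyond the scatter), and it is modest and beyond the scatter. Compound 1 differs from compound 3 in more than one place and gives no guide to this change. Among the compounds with values here, no measured compound carries the entering group, so the data do not fix the direction. Within the data shown here, a swap at this place has so far moved the number only modestly, so a step of similar or smaller size is expected in this assay, leaning slightly upward from the lowest value so far. The expected change is a 1.8-fold higher number from compound 3 to compound 4 (0.25 log units; within the scatter), which may not clear the scatter. For compound 4 the estimate is 30 nM, with an expected range of 10 nM to 90 nM.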

Compound 4, half-maximal inhibitory concentration: 124 nM
The estimate for compound 4 lay 4.1-fold (0.62 log units) below the measured number; the measured number lies above the stated range.
By their numbers in this assay, from the lowest: compound 3; then compound 2; then compound 4; then compound 1.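

At this place, on a saturated chain carbon bound to an aromatic carbon, the number in this assay now moves in both directions, and the new group goes the opposite way to the earlier 4-acetylpiperazin-1-yl change: 3-(dimethylamino)pyrrolidin-1-yl gives the rise (a 7.3-fold higher number from compound 3 to compound 4 (0.86 log units; beyond the scatter)) and also sits above the piperidin-1-yl group (a 2.5-fold higher number from compound 2 to compound 4 (0.39 log units; beyond the scatter)). Both steps are beyond the scatter, so the three groups fall in a clear order, with 4-acetylpiperazin-1-yl lowest, piperidin-1-yl in the middle and 3-(dimethylamino)pyrrolidin-1-yl highest, which shows that the number at this place depends on which group is attached rather than tolerating any of them equally. Nothing measured here accounts for that order.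

The compounds shown leave open whether the low number belongs to the acetyl group or to the piperazine ring, a question that 4-methylpiperazin-1-yl or morpholin-4-yl at this place would help separate. From the compounds shown here alone, it is equally open whether the rise in compound 4 goes with the five-membered ring or with the dimethylamino group, which 4-(dimethylamino)piperidin-1-yl would test.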